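The source may report more compounds than this note shows. Statements on the series, on what has been measured and on what is new or still open speak of the compounds shown alone.

Working notes on the series. Going by the values given here, in a functional assay on HepG2 cells (Homo sapiens) for antiproliferative activity, read by MTT assay, with a stated time of 24 h (a higher number here means a weaker inhibitor, a lower number a stronger inhibitor), compound 1 (`O=[N+]([O-])c1cccc(CSc2nnc(-c3ccc4c(c3)OCCO4)n2-c2ccccc2)c1`) gives 49300 nM and compound 2 (`O=[N+]([O-])c1ccc(CSc2nnc(-c3ccc4c(c3)OCCO4)n2-c2ccccc2)cc1`) gives 13800 nM, the lower of the two numbers so far. Among the compounds with values here, the single measured step, a 3.6-fold lower number from compound 1 to compound 2 (0.55 log units; beyond the scatter), is modest and swaps 3-nitrophenyl for 4-nitrophenyl on a saturated chain carbon bound to a sulfur. Next is compound 3 (`Clc1ccccc1CSc1nnc(-c2ccc3c(c2)OCCO3)n1-c1ccccc1`), with 2-chlorophenyl in place of 4-nitrophenyl at the same place: 2-chlorophenyl in place of 4-nitrophenyl on a saturated chain carbon bound to a sulfur. Within the data shown here, no measured compound carries 2-chlorophenyl, so that step bears only indirectly, as a guide to size. The working range runs from compound 2 at 13800 nM to compound 1 at 49300 nM. A step of similar modest size is therefore expected in this assay, towards a higher number. The expected change is a 2.0-fold higher number from compound 2 to compound 3 (0.31 log units; beyond the scatter). The estimate for compound 3 is 28000 nM, with an expected range of 10000 nM to 80000 nM.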

Compound 3, half-maximal inhibitory concentration: 970 nM
The estimate for compound 3 lay 29-fold (1.46 log units) above the measured number, outside the stated range (below it).
By their numbers in this assay, from the lowest: compound 3; then compound 2; then compound 1.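

In this assay, the group on the saturated chain carbon bound to sulfur can shift the number far more than the modest step between the two nitrophenyl isomers indicated: a 14-fold lower number from compound 2 to compound 3 (1.15 log units; beyond the scatter) and a 51-fold lower number from compound 1 to compound 3 (1.71 log units; beyond the scatter). Compound 3 is the strongest of the three, so a nitro group is not needed for activity in this series. Both steps change the substituent and its ring position together, as 3-nitrophenyl or 4-nitrophenyl gives way to 2-chlorophenyl, so neither change can be credited alone.

No supporting data bear on the reason for this large gain. From the compounds shown here alone, it remains open whether the gain follows the chlorine or its ring position, a question that 2-nitrophenyl and 4-chlorophenyl at this place would separate, and whether unsubstituted phenyl or 2-methoxyphenyl would keep it.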